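A few compounds are considered here, and "the series" means these few. Any claim that something is new, unique, unknown or untested is made for them only; others in the source may bear on it.

Three compounds that share one core and end in a urea linked to a substituted phenyl ring have been tested in a functional assay on MOLT-4 cells (Homo sapiens) for inhibition, read by sulforhodamine B assay, with a stated time of 48 h, tested at 100 uM; a higher number here means a weaker effect of the compound at the concentration tested, a lower number a stronger effect. Compound 1 `COc1cc(Cl)cc(-c2nn(-c3cccc(NC(=O)Nc4ccc(Cl)c(C(F)(F)F)c4)c3)cc2-c2ccncc2)c1` gives -28%, compound 2 `COc1cc(Cl)cc(-c2nn(-c3cccc(NC(=O)Nc4ccc(Cl)c(Cl)c4)c3)cc2-c2ccncc2)c1` gives -7%, and compound 3 `COc1cc(Cl)cc(-c2nn(-c3cccc(NC(=O)Nc4cccc(C(F)(F)F)c4)c3)cc2-c2ccncc2)c1` gives -36%. Compound 3 has the lowest of these three numbers; its gap to compound 1 lies within the scatter, while the step of a number 29 percentage points lower from compound 2 to compound 3 (beyond the scatter) lies beyond it, as does the step of a number 21 percentage points higher from compound 1 to compound 2 (beyond the scatter). The step of a number 8 percentage points lower from compound 1 to compound 3 (within the scatter) stays within the scatter.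

Compound 4 `COc1cc(Cl)cc(-c2nn(-c3cccc(NC(=O)c4cccc(C(F)(F)F)c4)c3)cc2-c2ccncc2)c1` differs from compound 3 in a single place: 3-(trifluoromethyl)phenyl in place of (3-(trifluoromethyl)phenyl)amino on a carbonyl carbon The urea of compound 3 thus becomes a plain amide. Going by the values given here, none of the measured steps touches this part of the molecule; all of them changed only the substituents on the terminal ring, and even the largest of them was modest. With no direct guide, a step of at most similar size is expected in this assay for compound 4, in either direction. Compound 4 is therefore estimated at -25%, between -50% and 5%, which corresponds to an expected step of a number 11 percentage points higher from compound 3 to compound 4 (beyond the scatter).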

Compound 4, a percentage reported as activity, at one concentration (the size of the read-out at that concentration, not a potency): 27%
For compound 4 the middle estimate is 52 percentage points below the measured one, outside the stated range (above it).
By their numbers in this assay, from the lowest: compounds 3 and 1 (each within the scatter of the next); then compound 2; then compound 4.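

Replacing the urea with a plain amide, which removes one amide-type nitrogen and its hydrogen-bond donor, changes the result far more than any substituent swap on the terminal ring did. In this assay this single change gives a number 63 percentage points higher from compound 3 to compound 4 (beyond the scatter) and marks the link itself as the most sensitive part of these molecules so far. The steps of a number 34 percentage points higher from compound 2 to compound 4 (beyond the scatter) and a number 55 percentage points higher from compound 1 to compound 4 (beyond the scatter) point the same way, although they also alter the ring substituents, and compound 4 has the weakest effect of the four at this concentration. Nothing available here explains why this change has so large an effect.

On these data alone, it remains open whether the nitrogen or its hydrogen matters, which a urea carrying a methyl group on that nitrogen could help separate. A carbamate at this link, or an amide with a 3,4-dichlorophenyl ring, would show how far the result extends.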